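The compounds below may be only part of what the source reports. "The series", "measured", "known", "first", "only" and "open" are said of these compounds alone.

Compound 1 `O=C(/C=C/c1ccc2c(c1)B(O)OC2)c1ccc(Cl)c(Cl)c1` gives a limit of > 10 ug/mL in an ADME assay on L929 cells (Mus musculus) for cytotoxicity, read by resazurin assay, with a stated time of 72 h; on this read-out higher numbers stand for weaker inhibition and lower numbers for stronger inhibition.
Compound 2 `O=C(/C=C/c1ccc2c(c1)B(O)OC2)c1ccc(C(F)(F)F)cc1` gives a limit of > 10 ug/mL in this assay.
Compound 3 `COc1ccc(C(=O)/C=C/c2ccc3c(c2)B(O)OC3)cc1OC` gives a limit of > 10 ug/mL in this assay.

Compound 2 stands where the other two stand, at the limit of > 10 ug/mL in this assay, at which 3 of the 3 values shown sit; its value is a limit, not a number. Compound 4 `CCc1ccc(C(=O)/C=C/c2ccc3c(c2)B(O)OC3)cc1` has not yet been measured in this assay and differs from compound 2 by ethyl in place of trifluoromethyl on an aromatic carbon. Among the measured compounds shown here, no step between measured compounds is available, and every value shown is a limit; the size of a step in this assay is therefore unknown here. The step that the limit leaves unreadable from compound 2 to compound 4 is expected to be none beyond the scatter. Compound 4 is expected to give 15 ug/mL in this assay, in the range 7 ug/mL to 40 ug/mL, most likely reported again as a limit.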

Compound 4, half-maximal inhibitory concentration: > 10 ug/mL
Compound 4: a limit, no number; the forecaster's own chance of this, stated with the estimate: 80%; the middle value lies beyond the limit too.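

In this assay compound 4 gives > 10 ug/mL, which is a limit. Among the compounds shown here, compound 2 also gives only a limit, so no step from compound 2 to compound 4 can be read. The compounds shown leave open whether ethyl and trifluoromethyl differ at all in this assay.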